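The source may report more compounds than this note shows. Statements on the series, on what has been measured and on what is new or still open speak of the compounds shown alone.

Of the compounds shown here, three that share one core have been measured in a functional assay on KM12 cells (Homo sapiens) for inhibition, read by sulforhodamine B assay, with a stated time of 48 h, tested at 10 uM; a lower number here means less inhibition, a higher number more inhibition at the concentration tested (going by the name of the read-out). Compound 1 `O=Cc1ccc(-c2cn3ccnc3c(-c3ccc4ncn(C5CCCCC5)c4c3)n2)cc1` gives 3.69%. Compound 2 `CCc1ccc(-c2cn3ccnc3c(-c3ccc4ncn(Cc5ccccc5)c4c3)n2)cc1` gives 45.7%, and compound 3 `Cc1cccc(-c2cn3ccnc3c(-c3ccc4ncn(Cc5ccccc5)c4c3)n2)c1` gives 22.1%. Compound 3 thus stands second highest of the three numbers: compound 1 lies beyond the scatter below it, while compound 2 lies beyond the scatter above it. Going by the values given here, the only step between measured neighbours, a number 23.6 percentage points lower from compound 2 to compound 3 (beyond the scatter), shows that exchanging one carbon-only ring for another on the same aromatic carbon shifted the read-out by a modest amount.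

Compound 4 `O=Cc1ccc(-c2cn3ccnc3c(-c3ccc4ncn(Cc5ccccc5)c4c3)n2)cc1` is compound 3 with one change: 4-formylphenyl in place of 3-methylphenyl on an aromatic carbon. Among the compounds with values here, no measured step matches this change exactly. The closest hint comes from a compound that carries the same 4-formylphenyl group but differs from compound 4 in a second place too: that is compound 1, which gives the lowest reading, 3.69%. That reading suggests the 4-formylphenyl compounds sit low in this series, though one example cannot settle it. Compound 4 is therefore expected to give about 12%, with a likely range from 0% to 32%. This estimate means a step of a number 10.1 percentage points lower from compound 3 to compound 4 (beyond the scatter) is expected, downward and beyond the scatter.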

Compound 4, a percentage reported as inhibition, at one concentration (the size of the read-out at that concentration, not a potency): 3.69%
The estimate for compound 4 lay 8.3 percentage points above the measured number; the range from low to high includes it.
By their numbers in this assay, from the lowest: compounds 1 and 4 (each within the scatter of the next); then compound 3; then compound 2.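

In this assay, 4-formylphenyl in place of 3-methylphenyl on this aromatic carbon gives a number 18.4 percentage points lower from compound 3 to compound 4 (beyond the scatter), while formyl in place of ethyl, a swap that keeps the substituent at the 4 position of the phenyl ring, gives a number 42 percentage points lower from compound 2 to compound 4 (beyond the scatter); the larger drop shows that changing the group alone, without moving it around the ring, can shift this reading strongly. Benzyl in place of cyclohexyl on the aromatic nitrogen gives no change at the digits printed from compound 1 to compound 4 (within the scatter), so among compounds carrying 4-formylphenyl, this change at the other site leaves the reading within the scatter, although this single pair cannot show whether the same holds with other aryl groups. No measurement offered here explains these shifts.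

As far as these compounds go, whether a 4-aminophenyl or 4-carboxyphenyl group on this carbon would read nearer the ethyl or the formyl compound remains open. It is also unknown whether a 3-formylphenyl group would differ from 4-formylphenyl, or whether 4-ethylphenyl would keep its higher reading with cyclohexyl on the nitrogen.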